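The source may report more compounds than this note shows. Statements on the series, on what has been measured and on what is new or still open speak of the compounds shown alone.

Both compounds measured so far were tested in a functional assay on HL-60 cells (Homo sapiens) for inhibition, read by MTT assay, with a stated time of 72 h (a lower number here means a stronger inhibitor, a higher number a weaker inhibitor), with these results:

- compound 1 `CCOc1cccc(N2CCN(C(=O)c3oc(C)nc3-c3ccccc3)CC2)c1` gives 151 nM
- compound 2 `Cc1nc(-c2ccccc2)c(C(=O)N2CCN(c3cccc(C(F)(F)F)c3)CC2)o1` gives 153 nM

Compound 2 stands at 153 nM in this assay and lies within the scatter of compound 1, so neither can be ranked above the other. The open question is compound 3 `Cc1nc(-c2ccccc2)c(C(=O)N2CCN(c3cccc(C#N)c3)CC2)o1` which has not yet been measured. It departs from compound 2 by cyano in place of trifluoromethyl on an aromatic carbon and so carries cyano in place of trifluoromethyl on an aromatic carbon, meta to a large group.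

Within the data shown here, one measured step bears on this change. That step, a 1.0-fold higher number from compound 1 to compound 2 (0.01 log units; within the scatter) is trifluoromethyl in place of ethoxy on an aromatic carbon, and it stays within the scatter. Among the measured compounds shown here, no measured compound carries cyano, so the evidence is thin. For the measured compounds named here, with that single step as the only guide, no step beyond the scatter is expected in this assay and no firm direction can be given. The expected change is a 1.1-fold higher number from compound 2 to compound 3 (0.05 log units; within the scatter) and it is estimated to stay within the scatter. For compound 3 the estimated value is 170 nM with an expected range from 65 nM to 450 nM around it.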

Compound 3, half-maximal inhibitory concentration: 39.6 nM
Compound 3: the middle estimate sits 4.3-fold (0.63 log units) above what was measured; the whole stated range lies above it.
By their numbers in this assay, from the lowest: compound 3; then compounds 1 and 2 (each within the scatter of the next).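

In this assay, the place on the aromatic ring, meta to a large group, proved sensitive to the group it carries: ethoxy and trifluoromethyl could not be told apart there, but cyano gives a 3.9-fold lower number from compound 2 to compound 3 (0.59 log units; beyond the scatter) and a 3.8-fold lower number from compound 1 to compound 3 (0.58 log units; beyond the scatter) in the two single changes that lead to it. Both steps are modest yet beyond the scatter, so compound 3 is the strongest inhibitor of the three, and this position is shown to offer room for a gain that the earlier pair gave no sign of. Cyano differs from trifluoromethyl in having fewer heavy atoms, a triple bond and a hydrogen-bond acceptor, but no measurement at hand connects the lower number to any one of these features or explains it.

Going by these compounds, whether the gain is particular to cyano remains open, since a single chlorine atom, an acetyl group or a carboxylic acid at this same place could fall on either side of it. Also open, on these data alone, is whether the step from trifluoromethyl to cyano would keep its size if the shared core were changed elsewhere.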